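Moving a Methyl Around an Imidazole Ring

This account rests on a few compounds, and the source may have more. Where it says the series, first, only, none or still open, it means among the compounds named here.

Three measured compounds share one core. Compound 1 `CSc1cc(C)c(C(=O)N=C(N)N)cc1S(C)(=O)=O` gives 6 nM in a functional assay for inhibition of sodium/hydrogen exchanger (Oryctolagus cuniculus) (a higher number here means a weaker inhibitor, a lower number a stronger inhibitor), and compound 2 `Cc1cc(OC(C)(C)C)c(S(C)(=O)=O)cc1C(=O)N=C(N)N` gives 9.4 nM, a step of a 1.6-fold higher number from compound 1 to compound 2 (0.19 log units; within the scatter). Compound 3 `Cc1cc(-n2ccnc2C)c(S(C)(=O)=O)cc1C(=O)N=C(N)N` gives 29 nM, the highest of the three numbers; the steps of a 4.8-fold higher number from compound 1 to compound 3 (0.68 log units; beyond the scatter) and a 3.1-fold higher number from compound 2 to compound 3 (0.49 log units; beyond the scatter) both lie beyond the scatter. Compound 4 `Cc1cn(-c2cc(C)c(C(=O)N=C(N)N)cc2S(C)(=O)=O)cn1` is built from the same atoms joined differently: 4-methyl-1H-imidazol-1-yl in place of 2-methyl-1H-imidazol-1-yl on an aromatic carbon. For the measured compounds named here, none of the measured steps bears directly on this change, since each of them swaps the whole group rather than the placement of the methyl within the imidazole ring. The step from compound 3 to compound 4 is therefore expected to stay within the scatter, a 1.0-fold lower number from compound 3 to compound 4 (0.02 log units; within the scatter). Compound 4 is estimated at 28 nM, in the range 10 nM to 80 nM.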

Compound 4, half-maximal inhibitory concentration: 28 nM
For compound 4 middle estimate and measured number coincide at the digits printed, and the stated range covers the measured number.
By their numbers in this assay, from the lowest: compounds 1 and 2 (each within the scatter of the next); then compounds 4 and 3 (each within the scatter of the next).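

In this assay the two placements of the methyl, 2-methyl-1H-imidazol-1-yl and 4-methyl-1H-imidazol-1-yl, give numbers within the scatter of each other, with a 1.0-fold lower number from compound 3 to compound 4 (0.02 log units; within the scatter) as the step. The gap to the two smaller groups also holds for the new placement, with a 3.0-fold higher number from compound 2 to compound 4 (0.47 log units; beyond the scatter) and a 4.7-fold higher number from compound 1 to compound 4 (0.67 log units; beyond the scatter) as its steps, so that gap does not depend on the methyl sitting at the 2-position alone. Going by these compounds, whether an imidazole carrying an amine or a carboxylic acid in place of the methyl would give a similar number stays open. Nothing shown gives a cause for any of these steps.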